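A few compounds are considered here, and "the series" means these few. Any claim that something is new, unique, unknown or untested is made for them only; others in the source may bear on it.

Among the measured compounds shown here, in a functional assay on HOP-62 cells (Homo sapiens) for inhibition, read by sulforhodamine B assay (on this read-out lower numbers stand for stronger inhibition of growth and higher numbers for weaker inhibition of growth), compound 1 (`Cc1ccc2[nH]c(-c3ccc(-c4ccc(-c5cccc(Cl)c5)cc4)cc3)nc2c1`) gives 2740 nM, the lowest of the three numbers so far. Compound 3 (`COc1cc(-c2ccc(-c3ccc(-c4nc5ccccc5[nH]4)cc3)cc2)cc(OC)c1OC`) gives 9430 nM, and compound 2 (`Clc1cccc(-c2ccc(-c3ccc(-c4nc5ccccc5[nH]4)cc3)cc2)c1`) gives 100000 nM, the highest. The unmeasured compound 4 (`Cc1ccc2[nH]c(-c3ccc(-c4ccc(-c5ccc(C(F)(F)F)cc5)cc4)cc3)nc2c1`) keeps the methyl of compound 1 and changes one group: 4-(trifluoromethyl)phenyl in place of 3-chlorophenyl on an aromatic carbon. In words, this is 4-(trifluoromethyl)phenyl in place of 3-chlorophenyl on an aromatic carbon.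

For the measured compounds named here, the only measured step is a 36-fold higher number from compound 1 to compound 2 (1.56 log units; beyond the scatter). It is large, but it concerns the methyl, which compound 4 retains, and so it bears only indirectly on this exchange. Going by the values given here, no measured step covers the exchange itself. Compound 2 and compound 3 both lack the methyl and differ in the group that changes here, and their values lie well apart, with compound 2 at 100000 nM and compound 3 at 9430 nM. A real shift therefore cannot be ruled out, but its size is poorly defined. Among the compounds with values here, compound 1 holds the lowest number so far, at 2740 nM, so a moderate move toward a higher number is expected. The expected step is a 1.6-fold higher number from compound 1 to compound 4 (0.22 log units; within the scatter). For compound 4 the estimate is 4500 nM, with an expected range of 1500 nM to 20000 nM.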

Compound 4, concentration for 50% growth inhibition: 24200 nM
Estimate against measurement, compound 4: 5.4-fold (0.73 log units) below; the whole stated range lies below it.
By their numbers in this assay, from the lowest: compound 1; then compound 3; then compound 4; then compound 2.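

With the methyl held constant, the exchange of 3-chlorophenyl for 4-(trifluoromethyl)phenyl gives an 8.8-fold higher number from compound 1 to compound 4 (0.95 log units; beyond the scatter) in this assay, which shows that this aromatic carbon also affects the read-out and that the methyl is not the only site that does. The earlier step, a 36-fold higher number from compound 1 to compound 2 (1.56 log units; beyond the scatter), concerned only the methyl; the new step is smaller, and both single changes from compound 1 lead to a higher number. Nothing measured here offers a reason for the size of the new step.

The exchange alters both the group and its place on the ring, so the compounds shown do not separate the change from chlorine to trifluoromethyl from the change from 3-substitution to 4-substitution. Also open, going by these compounds, are how a carboxylic acid or an amine on this ring would read in this assay, and whether the change seen on removing the methyl would hold with the aryl group of compound 3.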